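A 3-nitrophenyl group in place of 4-formylphenyl

The source may hold more compounds than are shown below. What is called first, only, known or untested is meant among the compounds shown, and "the series" means these compounds.

In a functional assay on SK-OV-3 cells (Homo sapiens) for inhibition, read by CCK-8 assay, with a stated time of 70 h (a higher number here means a weaker inhibitor, a lower number a stronger inhibitor), compound 3 `O=Cc1ccc(COc2ccc(OCCOCCNC3CCCC3)cc2)cc1` gives 45000 nM. Compound 2 `COC(=O)c1cccc(COc2ccc(OCCOCCNC3CCCC3)cc2)c1` gives 45500 nM, and a 1.0-fold lower number from compound 2 to compound 3 (0.00 log units; within the scatter) leaves the pair within the scatter. Compound 1 `COc1ccc(COc2ccc(OCCOCCNC3CCCC3)cc2)cc1` gives 15700 nM, and a 2.9-fold higher number from compound 1 to compound 3 (0.46 log units; beyond the scatter) shows compound 3 as the weaker of that pair, beyond the scatter.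

Compound 4 `O=[N+]([O-])c1cccc(COc2ccc(OCCOCCNC3CCCC3)cc2)c1` has not yet been measured. It carries 3-nitrophenyl in place of 4-formylphenyl on a saturated chain carbon bound to an oxygen on an aromatic ring, (3-nitrophenyl in place of 4-formylphenyl on a saturated chain carbon bound to an oxygen on an aromatic ring).

Among the measured compounds shown here, the closest precedent is the exchange of one aryl group for another among the non-methoxy compounds, a 1.0-fold lower number from compound 2 to compound 3 (0.00 log units; within the scatter). The two modest steps, a 2.9-fold higher number from compound 1 to compound 2 (0.46 log units; beyond the scatter) and a 2.9-fold higher number from compound 1 to compound 3 (0.46 log units; beyond the scatter), both leave the 4-methoxyphenyl group, which plays no part in the new change. No step beyond the scatter is therefore expected, and the estimated step is a 1.1-fold lower number from compound 3 to compound 4 (0.05 log units; within the scatter). For compound 4 the expected value is 40000 nM, with an estimated range of 18000 nM to 85000 nM.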

Compound 4, half-maximal inhibitory concentration: 15400 nM
For compound 4 the middle estimate is 2.6-fold (0.41 log units) above the measured one; measured number outside the range, below it.
By their numbers in this assay, from the lowest: compounds 4 and 1 (each within the scatter of the next); then compounds 3 and 2 (each within the scatter of the next).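

In this assay, exchanging one aryl group for another moved the number even with no 4-methoxyphenyl group involved, giving a 2.9-fold lower number from compound 3 to compound 4 (0.47 log units; beyond the scatter). The cleaner comparison is nitro in place of methoxycarbonyl on an aromatic carbon, with a 3.0-fold lower number from compound 2 to compound 4 (0.47 log units; beyond the scatter), so the group itself matters on this aryl ring and 4-methoxyphenyl is no longer alone at the low end, as a 1.0-fold lower number from compound 1 to compound 4 (0.01 log units; within the scatter) shows. No measurement shown here accounts for why these groups differ.

The step from compound 3 to compound 4 changes both the group and its printed ring numbering, so 4-nitrophenyl would be needed to separate the two. Going by these compounds, whether a nitrile, an amine or a carboxylic acid in place of the nitro would keep the number of compound 4 remains open.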